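The compounds below may be only part of what the source reports. "The series", "measured", "known", "first", "only" and "open" are said of these compounds alone.

Compound 1 `NS(=O)(=O)N1CCC(C(=O)/C(=N/O)Nc2ccc(F)c(Br)c2)CC1` in an assay on tissue (HeLa cells) for inhibition of Indoleamine 2,3-dioxygenase 1 (Homo sapiens), with a stated time of 48 h (a higher number here means a weaker inhibitor, a lower number a stronger inhibitor), gives 45 nM.
Compound 2 `O=C(/C(=N/O)Nc1ccc(F)c(Br)c1)C1CCCCC1` in this assay gives 63 nM.
Compound 3 `O=C(/C(=N/O)Nc1ccc(F)c(Br)c1)C1CCN(C(=O)Nc2ccccc2)CC1` in this assay gives 54 nM.

The three measured compounds share one core and differ only in the saturated ring and what it carries. Their numbers lie close together: compound 2 cannot be set apart from compound 3 or from compound 1, since both gaps are within the scatter of repeated measurements. Among the measured compounds shown here, the one step computed between measured compounds, a 1.2-fold higher number from compound 1 to compound 3 (0.08 log units; within the scatter), is also within the scatter, so exchanging one group on the ring nitrogen for another left the read-out essentially unchanged.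

Compound 4 `NS(=O)(=O)NC[C@H]1CC[C@H](C(=O)/C(=N/O)Nc2ccc(F)c(Br)c2)CC1` differs from compound 2 by (sulfamoylamino)methyl in place of hydrogen on a saturated ring carbon. For the measured compounds named here, no measured pair carries exactly this change. The closest guidance comes from compound 1 and compound 2, whose values show that a sulfamoyl group on the ring and an unsubstituted ring give numbers that are not separable. With every comparison so far falling within the scatter, the step from compound 2 to compound 4 in this assay is expected to be small, with at most a slight lowering of the number.

Compound 4 is therefore estimated at 45 nM, in a range from 20 nM to 110 nM, which corresponds to an expected step of a 1.4-fold lower number from compound 2 to compound 4 (0.15 log units; within the scatter).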

Compound 4, half-maximal inhibitory concentration: 21 nM
The estimate for compound 4 lay 2.1-fold (0.33 log units) above the measured number; the range from low to high includes it.
By their numbers in this assay, from the lowest: compound 4; then compounds 1, 3 and 2 (each within the scatter of the next).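

Among the compounds shown here, the step of a 3.0-fold lower number from compound 2 to compound 4 (0.48 log units; beyond the scatter) in this assay is the first one here to lie beyond the scatter, and it shows that this saturated ring carbon, three ring bonds from the ring atom that bears a large group, accepts (sulfamoylamino)methyl in place of hydrogen and that the number responds to that change. For the compounds shown here, the one earlier step, a 1.2-fold higher number from compound 1 to compound 3 (0.08 log units; within the scatter), exchanged one group for another on a ring nitrogen and stayed within the scatter, so it gave no sign that the read-out could move with the substituent on the saturated ring. Nothing given here accounts for the size of the new step, which is modest and rests on a single pair of compounds.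

The compounds shown leave open whether the change in the number needs the whole (sulfamoylamino)methyl group or only part of it, as a simple aminomethyl group, a carboxylic acid or a longer chain at the same ring carbon could tell. They also leave open how the opposite spatial arrangement of the two ring substituents would read out.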